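The source may report more compounds than this note shows. Statements on the series, on what has been measured and on what is new or still open speak of the compounds shown alone.

Four close relatives of one shared core are compared in a functional assay (Homo sapiens) for inhibition; a higher number here means a weaker inhibitor, a lower number a stronger inhibitor. Compound 1 `C[S+]([O-])c1ccc(CSc2nc(-c3ccc(Cl)cc3)c(-c3ccncc3)[nH]2)cc1` gives 320 nM in this assay. Compound 2 `CS(=O)(=O)c1ccc(CSc2nc(-c3ccc(Cl)cc3)c(-c3ccncc3)[nH]2)cc1` differs from it by a group of 4 heavy atoms (1 carbon, 2 oxygen, 1 sulfur; no ring) in place of a group of 3 heavy atoms (1 carbon, 1 oxygen, 1 sulfur; no ring), on an aromatic carbon; in this assay compound 2 gives 320 nM, so no change at the digits printed from compound 1 to compound 2 (within the scatter). Compound 3 `C[S+]([O-])c1ccc(CSc2nc(-c3ccc(Br)cc3)c(-c3ccncc3)[nH]2)cc1` differs from compound 1 by bromo in place of chloro on an aromatic carbon, and in this assay compound 3 gives 820 nM, which is a 2.6-fold higher number from compound 1 to compound 3 (0.41 log units; beyond the scatter). Among these three numbers, compound 3 stands highest.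

Compound 4 `CS(=O)(=O)c1ccc(CSc2nc(-c3ccc(Br)cc3)c(-c3ccncc3)[nH]2)cc1` has not yet been measured in this assay. It differs from compound 3 by a group of 4 heavy atoms (1 carbon, 2 oxygen, 1 sulfur; no ring) in place of a group of 3 heavy atoms (1 carbon, 1 oxygen, 1 sulfur; no ring), on an aromatic carbon. This is the same change already seen between compound 1 and compound 2, made at the same place on the same kind of ring, and the two cores differ only by bromo in place of chloro on an aromatic carbon. Since the earlier instance left the number unchanged within the scatter, the expected step here is no change at the digits printed from compound 3 to compound 4 (within the scatter), resting on the observation that no change at the digits printed from compound 1 to compound 2 (within the scatter). Compound 4 is therefore estimated to give 820 nM, with a likely range from 400 nM to 1700 nM.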

Compound 4, half-maximal inhibitory concentration: 640 nM
Compound 4: the middle estimate sits 1.3-fold (0.11 log units) above what was measured; low and high end bracket the measured number.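

In this assay, putting methylsulfonyl in place of the smaller sulfur group on the bromo compound gives a 1.3-fold lower number from compound 3 to compound 4 (0.11 log units; within the scatter), and this agrees with the same change on the chloro compounds: the same change on two cores in this assay, no change at the digits printed (within the scatter) from compound 1 to compound 2 and a 1.3-fold lower number (0.11 log units; within the scatter) from compound 3 to compound 4, 1.3-fold (0.11 log units) apart, within the scatter of two such steps. Read the other way, with methylsulfonyl held fixed, bromo in place of chloro gives a 2.0-fold higher number from compound 2 to compound 4 (0.30 log units; within the scatter), and this too agrees with the earlier step: the same change on two cores in this assay, a 2.6-fold higher number (0.41 log units; beyond the scatter) from compound 1 to compound 3 and a 2.0-fold higher number (0.30 log units; within the scatter) from compound 2 to compound 4, 1.3-fold (0.11 log units) apart, within the scatter of two such steps. So the two changes carry over between these compounds, but this rests on only four compounds whose cores differ by a single halogen, and it does not show that the same would hold on a core altered elsewhere, nor why the sulfur change makes so little difference here.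

The compounds shown leave open what a fluoro or a methoxy group would do in place of the chloro or bromo. They also leave open whether a sulfonamide, an amine or a carboxylic acid could stand in for methylsulfonyl with as little difference in the number.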